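The source may report more compounds than this note shows. Statements on the series, on what has been measured and on what is new or still open speak of the compounds shown alone.

Compound 2 `Cc1nc(-c2cccnc2)sc1-c1nnc(-c2ccc(Cl)cc2)o1` is the point of departure. In an ADME assay on PANC-1 cells (Homo sapiens) for cytotoxicity, read by MTT assay (a higher number here means that more compound is tolerated, a lower number that less compound is tolerated), compound 2 gives > 100 ug/mL, which is a limit of the assay rather than a number. Within the data shown here, its close relative compound 1 `Cc1nc(-c2cccnc2)sc1-c1nnc(-c2ccc(Br)cc2)o1` is the only other compound measured here. In this assay compound 1 likewise gives > 100 ug/mL, again a limit and not a number. Among the measured compounds shown here, the single measured step, a step that the two limits leave unreadable from compound 1 to compound 2, therefore cannot be sized: both ends sit at the limit of > 100 ug/mL in this assay, at which 2 of the 2 values shown sit.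

Compound 3 `Cc1nc(-c2cccnc2)sc1-c1nnc(-c2cccc(Cl)c2Cl)o1` is not yet measured. It differs from compound 2 by 2,3-dichlorophenyl in place of 4-chlorophenyl on an aromatic carbon. For the measured compounds named here, the one step that bears on this change is the halogen swap from compound 1 to compound 2, and it is unreadable, so nothing in the data gives a direction for a further change on the same phenyl group. Going by the values given here, both measured compounds sitting at the limit is the only guide, and on that basis compound 3 is expected to stay near that limit as well, a step that the limit leaves unreadable from compound 2 to compound 3 with no size beyond the scatter expected. For compound 3 in this assay the estimate is 120 ug/mL, within a range from 50 ug/mL to 300 ug/mL, and most likely reported again only as a limit.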

Compound 3, half-maximal cytotoxic concentration: > 100 ug/mL
Compound 3: no number, only a limit (the forecaster's own chance of this, stated with the estimate: 80%); the middle value does not contradict the limit.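

In this assay, among these compounds, compound 3 also gives only a limit, so no step among compound 1, compound 2 and compound 3 can be read, and all three stay at the same limit: the limit of > 100 ug/mL in this assay, at which 3 of the 3 values shown sit.

The compounds shown leave open what number each of the three would reach and whether any change on the phenyl group would bring a value under that limit.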